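The compounds below may be only part of what the source reports. "The series", "measured", "known", "first", "only" and "open" are said of these compounds alone.

Compound 1 `C/C=C/C(=O)N1CCCC(n2nc(-c3ccc(Oc4ccccc4)cc3)cc2C(=O)O)C1` is reported in a functional assay on JeKo-1 cells (Homo sapiens) for inhibition, read by luminescence and CellTiter-Glo, with a stated time of 72 h (on this read-out lower numbers stand for stronger inhibition and higher numbers for weaker inhibition), only as a limit, > 60000 nM. Compound 2 `O=C(CCl)Nc1cccc(Cn2nc(-c3ccc(Oc4ccccc4)cc3)cc2CO)c1` gives 400 nM. Compound 3 `O=C(CCl)Nc1cccc(Cn2nc(-c3ccc(Oc4ccccc4)cc3)cc2C(=O)O)c1` gives 6300 nM. Compound 4 `C/C=C/C(=O)N1CCCC(n2nc(-c3ccc(Oc4ccccc4)cc3)cc2CO)C1` has not been measured.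

From compound 3 to compound 2 the change is hydroxymethyl in place of carboxy on an aromatic carbon, and it made the step of a 16-fold lower number from compound 3 to compound 2 (1.20 log units; beyond the scatter). The change from compound 1 to compound 4 is hydroxymethyl in place of carboxy on an aromatic carbon, with the place described in the same words, so it is the same change. How the core of compound 1 differs from the core of compound 3 is not broken down here. Compound 1 stands at the limit of this assay, (the limit of > 60000 nM in this assay, at which 1 of the 3 values shown sits), so its value gives only a bound. The expected step is an at least 3.0-fold lower number from compound 1 to compound 4 (0.47 log units; beyond the scatter), resting on the step from compound 3 to compound 2 and on the limit of compound 1. Compound 4 is estimated at 20000 nM, between 3000 nM and 80000 nM.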

Compound 4, half-maximal inhibitory concentration: > 60000 nM
Compound 4: no number, only a limit; the forecaster's own chance of this, stated with the estimate: 40%; middle value at least 3.0-fold (0.47 log units) away from the limit.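

Compound 4 gives only a limit in this assay, > 60000 nM. Going by these compounds alone, compound 1 also stands at a limit, so no step from compound 1 to compound 4 can be read. Left open is whether hydroxymethyl in place of carboxy on an aromatic carbon changes the value on the core of compound 1.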